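This account rests on a few compounds, and the source may have more. Where it says the series, first, only, none or still open, it means among the compounds named here.

In a functional assay on MCF7 cells (Homo sapiens) for cytotoxicity, read by MTT assay, with a stated time of 72 h (a lower number here means a stronger inhibitor, a higher number a weaker inhibitor), compound 1 `COc1cccc(/C=C2\CCC/C(=C\c3ccc(Cl)cc3)C2=O)c1OC` gives 10300 nM and compound 2 `COc1cccc(/C=C2\CCC/C(=C\c3cccc(O)c3)C2=O)c1OC` gives 8800 nM, so compound 2 stands level with compound 1 within the scatter. Compound 3 `COc1cccc(/C=C2\CCC/C(=C\c3ccc(O)cc3)C2=O)c1OC` carries 4-hydroxyphenyl in place of 3-hydroxyphenyl on a double-bonded chain carbon bound to a double-bonded ring carbon. Within the data shown here, the only measured step at this place, a 1.2-fold lower number from compound 1 to compound 2 (0.07 log units; within the scatter), stayed within the scatter, so no step beyond the scatter is expected here. The expected change is a 1.1-fold lower number from compound 2 to compound 3 (0.04 log units; within the scatter). For compound 3 the estimate is 8000 nM, with an expected range of 3500 nM to 16000 nM.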

Compound 3, half-maximal inhibitory concentration: > 20000 nM
Compound 3 was reported as a limit; the forecaster's own chance of this, stated with the estimate: 5%; middle value at least 2.5-fold (0.39 log units) from the limit.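

Compound 3 is reported only as a limit, not as a number: the limit of > 20000 nM in this assay, at which 1 of the 3 values shown sits. In this assay, 4-hydroxyphenyl in place of 3-hydroxyphenyl gives an at least 2.2-fold higher number from compound 2 to compound 3 (0.35 log units; beyond the scatter), so with the same atoms joined differently, the result at this place still changes beyond the scatter, which the earlier step did not show. Hydroxy in place of chloro gives an at least 1.9-fold higher number from compound 1 to compound 3 (0.28 log units; that floor lies within the scatter), a floor that sets no clear order.

How 3-aminophenyl and 4-aminophenyl would compare at this place stays open, so the compounds shown cannot tell whether this split extends beyond hydroxy.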